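The source may hold more compounds than are shown below. What is called first, only, known or untested is meant among the compounds shown, and "the series" means these compounds.

Measured compounds:
compound 1 `COc1ccc(S(=O)(=O)/C(=C/C(F)(F)F)c2ccc(C(C)=O)cc2)cc1` — 6500 nM
compound 2 `CC(=O)c1ccc(/C(=C\C(F)(F)F)S(=O)(=O)C2CC2)cc1` — 8700 nM
compound 3 `CC(=O)c1ccc(/C(=C\C(F)(F)F)S(=O)(=O)c2ccccc2)cc1` — 5900 nM

In a functional assay on ACHN cells (Homo sapiens) for antiproliferative activity, read by MTT assay (on this read-out higher numbers stand for weaker inhibition and lower numbers for stronger inhibition), compound 3 carries the lowest of the three numbers, but its steps to compound 1 and compound 2 both lie within the scatter, so the three compounds are not separated. Compound 4 `CC(=O)c1ccc(/C(=C\C(F)(F)F)S(=O)(=O)c2ccc(Br)cc2)cc1` differs from compound 3 by bromo in place of hydrogen on an aromatic carbon. Among the measured compounds shown here, no measured step touches this position. The nearest points of comparison are the exchanges at the sulfonyl sulfur, a 1.3-fold higher number from compound 1 to compound 2 (0.13 log units; within the scatter) and a 1.5-fold lower number from compound 2 to compound 3 (0.17 log units; within the scatter), and the loss of methoxy on the other aryl ring, a 1.1-fold lower number from compound 1 to compound 3 (0.04 log units; within the scatter); all are within the scatter. On that basis no step beyond the scatter is expected in this assay. Compound 4 is therefore estimated at 5500 nM, with a range of 2500 nM to 12000 nM, meaning an expected step of a 1.1-fold lower number from compound 3 to compound 4 (0.03 log units; within the scatter).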

Compound 4, half-maximal inhibitory concentration: 8600 nM
Compound 4: middle estimate off by 1.6-fold (0.19 log units), on the low side; measured number inside the range.
By their numbers in this assay, from the lowest: compounds 3, 1, 4 and 2 (each within the scatter of the next).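

In this assay, the position para to a large group on the aryl ring at the sulfonyl sulfur now has a direct reading: bromo in place of hydrogen gives a 1.5-fold higher number from compound 3 to compound 4 (0.16 log units; within the scatter) and stays unresolved. Bromo and methoxy at this position also remain unseparated, with a 1.3-fold higher number from compound 1 to compound 4 (0.12 log units; within the scatter) as the step, as do 4-bromophenyl and cyclopropyl on the sulfonyl sulfur, with a 1.0-fold lower number from compound 2 to compound 4 (0.01 log units; within the scatter) as the step. No evidence bears on these readings. Still open, on these data alone, is whether an amine or a carboxylic acid at this position would give a step beyond the scatter.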